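This account rests on a few compounds, and the source may have more. Where it says the series, first, only, none or still open, it means among the compounds named here.

Compounds measured so far:

compound 1, `COc1ccccc1C(=O)Nc1ccc2[nH]cc(C3CCN(C)CC3)c2n1`, 20 nM
compound 2, `CN1CCC(c2c[nH]c3ccc(NC(=O)C4CCCCC4)nc23)CC1`, 20 nM
compound 3, `CC(=O)Nc1ncc2[nH]cc(C3CCN(C)CC3)c2n1`, 220 nM

All three numbers come from an assay for binding affinity to 5-hydroxytryptamine receptor 1F (Homo sapiens), read by radioligand binding; on this read-out higher numbers stand for weaker inhibition and lower numbers for stronger inhibition. Compound 2 stands level with compound 1, and these two together give the lowest numbers of the three, while compound 3 gives a higher number that lies beyond the usual scatter of this assay.

The unmeasured compound 4, `CN1CCC(c2c[nH]c3ccc(NC(=O)Nc4ccc(F)cc4)nc23)CC1`, is built from compound 2 by one change: (4-fluorophenyl)amino in place of cyclohexyl on a carbonyl carbon. Among the compounds with values here, the only measured step that bears on this position is the one where the group on the same carbonyl carbon was changed, no change at the digits printed from compound 1 to compound 2 (within the scatter). There, replacing an aromatic group with a non-aromatic ring on that carbonyl carbon left the number where it was, which suggests that this assay tolerates different groups on that carbon. Within the data shown here, no measured pair shows what a nitrogen placed directly on the carbonyl carbon does, so the new hydrogen-bond donor is an open question. On this basis the step is expected to be small, a 1.5-fold higher number from compound 2 to compound 4 (0.18 log units; within the scatter), with no clear direction beyond the scatter. Compound 4 is therefore estimated at 30 nM, within a range of 8 nM to 120 nM.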

Compound 4, inhibition constant: 11 nM
The estimate for compound 4 lay 2.7-fold (0.44 log units) above the measured number; the range from low to high includes it.
By their numbers in this assay, from the lowest: compounds 4, 1 and 2 (each within the scatter of the next); then compound 3.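

In this assay, (4-fluorophenyl)amino on the carbonyl carbon gives a 1.8-fold lower number from compound 2 to compound 4 (0.26 log units; within the scatter) and, set against the 2-methoxyphenyl group, gives a 1.8-fold lower number from compound 1 to compound 4 (0.26 log units; within the scatter) in this series. The earlier pair compared only an aromatic ring and a non-aromatic ring, each joined to the carbonyl carbon through carbon, whereas this group is joined through nitrogen, brings a hydrogen-bond donor and has a fluorine on its ring, yet the number stays within the scatter of both earlier compounds. So at this position, all three groups, despite these differences in how they are built, give numbers that cannot be told apart in this assay, although nothing shown here explains that tolerance.

From the compounds shown here alone, the change brought in the nitrogen and the fluorine together, so their separate contributions remain open, and how a plain phenylamino group, a longer alkyl chain or a carboxylic acid would read at this carbon is also unknown. Compound 3 differs from the others in more than one place, so its number cannot be assigned to any single change.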